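Cyclic Ether Side Chain on the Aminoquinoline Core

A few compounds are considered here, and "the series" means these few. Any claim that something is new, unique, unknown or untested is made for them only; others in the source may bear on it.

Of the compounds shown here, three sharing one core have been measured in an assay on cells with melanin-concentrating hormone receptor 1 (Homo sapiens) as the target, read by radioligand binding; a lower number here means a stronger inhibitor, a higher number a weaker inhibitor. Compound 1 `CCC(C)COc1cccc2ccc(N)nc12` gives 36 nM, compound 2 `CCOCC(C)Oc1cccc2ccc(N)nc12` gives 1070 nM, and compound 3 `CCCC(C)Oc1cccc2ccc(N)nc12` gives 105 nM. Within these three, compound 3 stands second highest, separated from compound 1 by a 2.9-fold higher number from compound 1 to compound 3 (0.46 log units; beyond the scatter) and from compound 2 by a 10-fold lower number from compound 2 to compound 3 (1.01 log units; beyond the scatter).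

Compound 4 `Nc1ccc2cccc(OCC3CCCO3)c2n1`, not yet measured, differs from compound 3 in one place: (oxolan-2-yl)methyl in place of 1-methylbutyl on an oxygen on an aromatic ring. The new group carries an oxygen in a ring, so the closest guides are the two measured steps in which an oxygen enters or leaves the side chain. Going from compound 1 to compound 2, an oxygen-containing chain replaced an all-carbon one and the result was a 30-fold higher number from compound 1 to compound 2 (1.47 log units; beyond the scatter). Going the other way, from compound 2 to compound 3, the oxygen left and the result was a 10-fold lower number from compound 2 to compound 3 (1.01 log units; beyond the scatter). Both steps point the same way: an oxygen in the side chain went with a higher number in this assay. Going by the values given here, the ring in compound 4 has no measured counterpart, so the size is uncertain, but a step of a 4.8-fold higher number from compound 3 to compound 4 (0.68 log units; beyond the scatter) is expected. Compound 4 is therefore estimated at 500 nM, within a range from 150 nM to 1800 nM.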

Compound 4, half-maximal inhibitory concentration: > 2000 nM
Compound 4: a limit, no number; the forecaster's own chance of this, stated with the estimate: 5%; at least 4.0-fold (0.60 log units) between middle value and limit.
By their numbers in this assay, from the lowest: compound 1; then compound 3; then compound 2. At a limit, above all of these: compound 4.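

In this assay, compound 4 gives a limit and not a number: the limit of > 2000 nM in this assay, at which 1 of the 4 values shown sits.

Placing (oxolan-2-yl)methyl on the oxygen on the aromatic ring in place of 1-methylbutyl gives an at least 19-fold higher number from compound 3 to compound 4 (1.27 log units; beyond the scatter), and oxolan-2-yl in place of the sec-butyl of the best compound here gives an at least 55-fold higher number from compound 1 to compound 4 (1.74 log units; beyond the scatter), so an oxygen held in a five-membered ring goes with a much higher number, just as the oxygen in the open chain of compound 2 did. Against that open chain, the step reads an at least 1.8-fold higher number from compound 2 to compound 4 (0.27 log units; that floor lies within the scatter); its floor lies within the scatter, so these data do not separate the ring ether of compound 4 from the open-chain ether of compound 2.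

The compounds shown leave open whether the ring oxygen or the ring itself goes with the higher number, and cyclopentylmethyl, the all-carbon counterpart of the new group, on the same oxygen would tell the two apart. Also open, from the compounds shown here alone, is whether a ring nitrogen, as in a pyrrolidin-2-ylmethyl group, would fare any differently from the ring oxygen.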